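Dithiolane amide series: coumarin substituent change from compound 2 to 3

A few compounds are considered here, and "the series" means these few. Any claim that something is new, unique, unknown or untested is made for them only; others in the source may bear on it.

Measured so far:
compound 1, `Cc1cc(=O)oc2cc(OCCCn3cc(CNC(=O)CCCCC4CCSS4)nn3)ccc12`, 44.8% 
compound 2, `CCOC(=O)c1cc2ccc(OCCCn3cc(CNC(=O)CCCCC4CCSS4)nn3)cc2oc1=O`, 28% 

In a functional assay on PC-12 cells (Rattus norvegicus) for cytotoxicity, read by MTT assay, with stated times of 3 h and 2 h, tested at 0.1 uM (a lower number here means a weaker effect, a higher number a stronger effect of the compound at the concentration tested), compound 1 gives 44.8% and compound 2 gives 28%. On these two numbers compound 2 stands lowest; its nearest neighbour is compound 1, whose number is higher by a margin beyond the scatter. Among the measured compounds shown here, no step between compounds that differ in one place is available, so nothing measured yet tells how a change on the shared core moves the read-out.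

Compound 3, `COc1ccc(-c2cc3ccc(OCCCn4cc(CNC(=O)CCCCC5CCSS5)nn4)cc3oc2=O)cc1`, has not been measured in this assay. It differs from compound 2 in one place: 4-methoxyphenyl in place of ethoxycarbonyl on an aromatic carbon. The leaving group and the entering group are both without donors, and the entering group brings one six-membered aromatic ring of carbon only where none stood before.

For the measured compounds named here, with no comparable step at hand, the expectation for compound 3 is a small rise in this assay, roughly of the order of the scatter, with the step of a number 7 percentage points higher from compound 2 to compound 3 (within the scatter) taken as the estimate. Compound 3 is thus estimated at 35%, within a range from 15% to 55%.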

Compound 3, a percentage reported as activity, at one concentration (the size of the read-out at that concentration, not a potency): 42%
Estimate against measurement, compound 3: 7 percentage points below, within the range that was stated.
By their numbers in this assay, from the lowest: compound 2; then compounds 3 and 1 (each within the scatter of the next).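

In this assay, among the compounds shown here, the aromatic carbon two atoms from the ring oxygen gives the first single-place comparison: 4-methoxyphenyl in place of ethoxycarbonyl gives a number 14 percentage points higher from compound 2 to compound 3 (beyond the scatter). The read-out at this position therefore responds to the group placed there, and a carbon-only aromatic ring bearing a methoxy group is tolerated here without any loss at the concentration tested. No measurement is available that would explain the step.

The compounds shown leave open whether the step follows the departure of ethoxycarbonyl or the arrival of 4-methoxyphenyl, and a plain phenyl, a carboxylic acid or a primary amine on this same carbon would begin to separate the two. Also open, on these data alone, are whether the step holds with a longer chain on the ether oxygen of the shared core and whether it would persist at other concentrations, since this single read-out is the size of an effect at one concentration and not a potency.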